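The source may hold more compounds than are shown below. What is called first, only, known or untested is meant among the compounds shown, and "the series" means these compounds.

Measured so far:
compound 1 `CCN(CC)CN1C(=O)/C(=N/NC(N)=S)c2cc(Cl)ccc21`: 148000 nM
compound 2 `CCN(CC)CN1C(=O)/C(=N/NC(=S)Nc2ccccc2)c2ccccc21`: 13000 nM

In a functional assay on L1210 cells (Mus musculus) for inhibition, read by cell counting, with a stated time of 48 h (a lower number here means a stronger inhibitor, a higher number a weaker inhibitor), compound 1 holds the higher of the two numbers, and compound 2 sits at the lower one by a margin beyond the scatter. Compound 3 `CCN(CC)CN1C(=O)/C(=N/NC(=S)Nc2ccc(OC)cc2)c2cc(Cl)ccc21` is the next point, derived from compound 1 by 4-methoxyphenyl in place of hydrogen on an amide-type nitrogen. Going by the values given here, no step between measured compounds is available, so the expected size of the move rests on the two values alone: a clear shift toward a lower number, a 9.9-fold lower number from compound 1 to compound 3 (0.99 log units; beyond the scatter), is expected because compound 2 gives 13000 nM. Compound 3 is therefore estimated at 15000 nM, with a range of 5000 nM to 50000 nM.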

Compound 3, half-maximal inhibitory concentration: 11000 nM
Compound 3: the middle estimate sits 1.4-fold (0.13 log units) above what was measured; low and high end bracket the measured number.
By their numbers in this assay, from the lowest: compounds 3 and 2 (each within the scatter of the next); then compound 1.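

In this assay, 4-methoxyphenyl in place of hydrogen on the amide-type nitrogen gives a 13-fold lower number from compound 1 to compound 3 (1.13 log units; beyond the scatter) as the first step read at a single position in this series. This nitrogen, whose other neighbour is the thiocarbonyl carbon, therefore accepts a large aromatic substituent, and activity improves beyond the scatter. Nothing available explains the size of this step.

Still open, from the compounds shown here alone, is whether the aromatic ring or its methoxy group carries the change. An ethyl chain or a 4-carboxyphenyl group on the same nitrogen would help separate these readings.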